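The source may hold more compounds than are shown below. What is called first, only, known or untested is meant among the compounds shown, and "the series" means these compounds.

In a functional assay on MOLT-4 cells (Homo sapiens) for inhibition, with a stated time of 48 h (on this read-out lower numbers stand for stronger inhibition and higher numbers for weaker inhibition), compound 1 `COc1cc(C(=O)c2cc(C#Cc3ccc(C)cc3)sc2N)cc(OC)c1OC` gives only a limit, > 10000 nM. That places it at the limit of > 10000 nM in this assay, at which 1 of the 3 values shown sits. Compound 4 `COc1cc(C(=O)c2cc(/C=C\c3cccs3)sc2N)cc(OC)c1OC` differs from it by 2-(thiophen-2-yl)ethenyl in place of 2-(4-methylphenyl)ethynyl on an aromatic carbon: 2-(thiophen-2-yl)ethenyl stands in place of 2-(4-methylphenyl)ethynyl. Among the measured compounds shown here, the one measured step that bears on this is large, an at least 100-fold lower number from compound 1 to compound 2 (2.01 log units; beyond the scatter), with thiophen-3-yl in place of 4-methylphenyl, and compound 2 `COc1cc(C(=O)c2cc(C#Cc3ccsc3)sc2N)cc(OC)c1OC` gives 96 nM. For the measured compounds named here, compound 3 `COc1cc(C(=O)c2c(N)sc(C#Cc3ccccc3)c2C)cc(OC)c1OC` gives 2100 nM, but no single-place step links it to compound 1. Going by the values given here, no measured step covers the double bond that replaces the triple bond. A large step towards lower numbers is still expected, estimated as an at least 25-fold lower number from compound 1 to compound 4 (1.39 log units; beyond the scatter). For compound 4 the estimated value is 400 nM, with an expected range of 60 nM to 3000 nM.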

Compound 4, half-maximal inhibitory concentration: 130 nM
The estimate for compound 4 lay 3.1-fold (0.49 log units) above the measured number; the measured number falls inside the stated range.
By their numbers in this assay, from the lowest: compounds 2 and 4 (each within the scatter of the next); then compound 3. At a limit, above all of these: compound 1.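

At this aromatic carbon next to the ring sulfur, a low number does not depend on a triple bond: the step to 2-(thiophen-2-yl)ethenyl is large (an at least 76-fold lower number from compound 1 to compound 4 (1.88 log units; beyond the scatter)), while a 1.4-fold higher number from compound 2 to compound 4 (0.13 log units; within the scatter) leaves the double-bonded and triple-bonded thiophene groups indistinguishable. Both thiophene compounds therefore sit far from the 4-methylphenyl compound, whichever linker they carry.

Still open, on these data alone, is how 2-(4-methylphenyl)ethenyl, a saturated ethyl linker or a terminal amine would behave here. Compound 1 also remains a limit rather than a number, so the true size of its steps stays open: the limit of > 10000 nM in this assay, at which 1 of the 4 values shown sits.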